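The source may hold more compounds than are shown below. What is called first, only, known or untested is meant among the compounds shown, and "the series" means these compounds.

Measured so far in an ADME assay on HEL cells (Homo sapiens) for cytotoxicity; a lower number here means that less compound is tolerated, a higher number that more compound is tolerated:
- compound 1, `C/C(=N\NC(=O)COc1cccc2ccccc12)c1ccc(C#N)cc1Br`: 20 ug/mL
- compound 2, `C/C(=N\NC(=O)COc1cccc2ccccc12)c1ccccc1`: 20 ug/mL
- compound 3, `C/C(=N\NC(=O)COc1cccc2ccccc12)c1ccc([N+](=O)[O-])cc1`: 100 ug/mL

Compound 3 holds the highest of the three numbers. Its nearest neighbour is compound 1, reached by a 5.0-fold higher number from compound 1 to compound 3 (0.70 log units; beyond the scatter); the gap to compound 2 is the same size, a 5.0-fold higher number from compound 2 to compound 3 (0.70 log units; beyond the scatter). Compound 1 and compound 2, for their part, sit together: no change at the digits printed from compound 1 to compound 2 (within the scatter).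

Compound 4, `C/C(=N\NC(=O)COc1cccc2ccccc12)c1ccc(Cl)cc1`, is not yet measured. It differs from compound 3 in one place: chloro in place of nitro on an aromatic carbon. The step that bears most directly on this is the reverse of a 5.0-fold higher number from compound 2 to compound 3 (0.70 log units; beyond the scatter), since the nitro that entered there now leaves. On these data alone, nothing measured shows chloro in place of hydrogen at that position, so the effect of the entering group is unknown. The working expectation is that removing the nitro undoes most of the rise seen in this assay, bringing compound 4 back toward the numbers of compound 1 and compound 2, with the chloro left as the open question. The expected step is a 3.3-fold lower number from compound 3 to compound 4 (0.52 log units; beyond the scatter). Compound 4 is therefore estimated at 30 ug/mL, within a range of 10 ug/mL to 100 ug/mL.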

Compound 4, minimum cytotoxic concentration: >= 4 ug/mL
Compound 4 was reported as a limit (the forecaster's own chance of this, stated with the estimate: 5%); the middle value does not contradict the limit.
By their numbers in this assay, from the lowest: compounds 1 and 2 (each within the scatter of the next); then compound 3.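

In this assay compound 4 gives >= 4 ug/mL, which is a limit and not a number. The steps linking it to compound 1, compound 2 and compound 3 cannot be read. The compounds shown leave open what chloro, in place of hydrogen or nitro, does to this number.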